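A few compounds are considered here, and "the series" means these few. Any claim that something is new, unique, unknown or untested is made for them only; others in the source may bear on it.

For the measured compounds named here, in a functional assay on IMR-32 cells (Homo sapiens) for antiproliferative activity, read by sulforhodamine B assay, with a stated time of 48 h (a lower number here means a stronger inhibitor of growth, a higher number a weaker inhibitor of growth), three compounds built on a shared core have numbers so far. Compound 1 (`Cc1ccc(-c2cn(CCCN3C(=O)COc4ccccc43)nn2)cc1`) gives 4400 nM, compound 2 (`CCCCCCc1cn(CCCN2C(=O)COc3ccccc32)nn1`) gives 710 nM and compound 3 (`CCCCc1cn(CCCN2C(=O)COc3ccccc32)nn1`) gives 5700 nM. Compound 3 thus sits together with compound 1 at the high end of these numbers, the two lying within the scatter of each other. Compound 4 (`O=C1COc2ccccc2N1CCCn1cc(C2(O)CCCCC2)nn1`) has 1-hydroxycyclohexyl in place of butyl on an aromatic carbon.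

All three measured steps change the group on that aromatic carbon. Butyl for 4-methylphenyl gives a 1.3-fold higher number from compound 1 to compound 3 (0.11 log units; within the scatter), which is within the scatter. Hexyl for 4-methylphenyl gives a 6.2-fold lower number from compound 1 to compound 2 (0.79 log units; beyond the scatter), and the shorter chain gives an 8.0-fold higher number from compound 2 to compound 3 (0.90 log units; beyond the scatter), both modest steps beyond the scatter. Going by the values given here, no measured compound carries a 1-hydroxycyclohexyl group, so the direction of any change is poorly defined. With compound 1 at 4400 nM, a ring-bearing group matches butyl here, so no step beyond the scatter is expected: a 1.1-fold lower number from compound 3 to compound 4 (0.06 log units; within the scatter). Compound 4 is estimated at 5000 nM, within an expected range of 1500 nM to 17000 nM.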

Compound 4, concentration for 50% growth inhibition: 1200 nM
Beside the measured number, compound 4's estimate is 4.2-fold (0.62 log units) above it, and the stated range ends above it.
By their numbers in this assay, from the lowest: compounds 2 and 4 (each within the scatter of the next); then compounds 1 and 3 (each within the scatter of the next).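

In this assay, 1-hydroxycyclohexyl on this aromatic carbon gives a 4.8-fold lower number from compound 3 to compound 4 (0.68 log units; beyond the scatter) and a 3.7-fold lower number from compound 1 to compound 4 (0.56 log units; beyond the scatter), so a group bearing a ring is not tied to the high end of the numbers at this position, where the 4-methylphenyl of compound 1 stands. For the compounds shown here, the step to the hexyl compound, a 1.7-fold higher number from compound 2 to compound 4 (0.23 log units; within the scatter), lies within the scatter, which shows that hexyl is not the only group here that reaches the low end, and that a non-aromatic ring with a hydroxyl group can do so too. Nothing available explains this result.

From the compounds shown here alone, it remains open whether the gain from butyl comes from the ring or from the hydroxyl group, which plain cyclohexyl would help to separate. Also open, going by these compounds, is how an amine in place of that hydroxyl group, or a chain longer than hexyl, would behave at this carbon.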